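This account rests on a few compounds, and the source may have more. Where it says the series, first, only, none or still open, it means among the compounds named here.

Compound 1 `COc1cc(OC)c(-c2coc3cc(OCC(=O)c4cccc(C(F)(F)F)c4)ccc3c2=O)cc1OC`: > 10000 nM
Compound 2 `COc1cc(OC)c(-c2coc3cc(OCc4ccccc4C#N)ccc3c2=O)cc1OC`: 980 nM
Compound 3 `COc1cc(OC)c(-c2coc3cc(OCc4cccc(Cl)c4)ccc3c2=O)cc1OC`: > 10000 nM

In a functional assay on U-251 cells (Homo sapiens) for antiproliferative activity, read by MTT assay, with a stated time of 24 h (a higher number here means a weaker inhibitor, a lower number a stronger inhibitor), compound 3 gives > 10000 nM, which is a limit and not a number. Compound 3 thus stands at the limit of > 10000 nM in this assay, at which 2 of the 3 values shown sit. Only compound 2 gives a true number, 980 nM.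

Compound 4 `COc1cc(OC)c(-c2coc3cc(OCc4ccccc4Br)ccc3c2=O)cc1OC` carries 2-bromophenyl in place of 3-chlorophenyl on a saturated chain carbon bound to an oxygen on an aromatic ring. The most relevant measured step is an at least 10-fold higher number from compound 2 to compound 3 (1.00 log units; beyond the scatter), where 3-chlorophenyl replaced 2-cyanophenyl. Among the compounds with values here, the step of an at least 10-fold lower number from compound 1 to compound 2 (1.00 log units; beyond the scatter) also leads to the only compound with a true number. Compound 4 shares the 2 in its group name with compound 2, so a lower number in this assay is expected, though probably a smaller gain and another limit remains possible. The expected step is an at least 3.3-fold lower number from compound 3 to compound 4 (0.52 log units; beyond the scatter). Compound 4 is estimated at 3000 nM, with an expected range from 800 nM to 12000 nM.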

Compound 4, half-maximal inhibitory concentration: > 10000 nM
Compound 4: no number, only a limit; the forecaster's own chance of this, stated with the estimate: 35%; at least 3.3-fold (0.52 log units) between middle value and limit.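

Putting bromo in place of cyano on that aromatic carbon gives an at least 10-fold higher number from compound 2 to compound 4 (1.00 log units; beyond the scatter) in this assay. So the 2 in the group name does not bring activity by itself: among the compounds shown, only the 2-cyanophenyl group gives a true number. Compound 4, like compound 1 and compound 3, gives only a limit, and the steps among these three cannot be read: the limit of > 10000 nM in this assay, at which 3 of the 4 values shown sit.

Still open, on these data alone, is whether the nitrile itself is what counts. A 2-aminophenyl or 2-methoxyphenyl group in the same place could show whether other groups also give a true number.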